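Removal of one hydroxy from the dihydroxyphenyl imine

The source may hold more compounds than are shown below. What is called first, only, known or untested is meant among the compounds shown, and "the series" means these compounds.

Measured in a functional assay, with a stated time of 30 min; a higher number here means a weaker inhibitor, a lower number a stronger inhibitor:
compound 1, `CCCCc1oc2ccc(/N=C/c3ccc(Cl)cc3)cc2c1C(=O)c1ccc(OC)cc1`, gives 75.9 ug/mL
compound 2, `CCCCc1oc2ccc(/N=C/c3ccccc3)cc2c1C(=O)c1ccc(OC)cc1`, gives 34.2 ug/mL
compound 3, `CCCCc1oc2ccc(/N=C/c3ccc(O)cc3O)cc2c1C(=O)c1ccc(OC)cc1`, gives 7.55 ug/mL

Compound 3 has the lowest number of the three, with the steps of a 4.5-fold lower number from compound 2 to compound 3 (0.66 log units; beyond the scatter) and a 10-fold lower number from compound 1 to compound 3 (1.00 log units; beyond the scatter) both beyond the scatter. Compound 4, `CCCCc1oc2ccc(/N=C/c3ccccc3O)cc2c1C(=O)c1ccc(OC)cc1`, differs from compound 3 by hydrogen in place of hydroxy on an aromatic carbon.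

For the measured compounds named here, no measured step removes a single hydroxy. The nearest guide is the step from a bare phenyl to the dihydroxyphenyl, a 4.5-fold lower number from compound 2 to compound 3 (0.66 log units; beyond the scatter); taking one of the two hydroxy groups away is expected to give back part of that gain, so compound 4 is expected to land between compound 3 and compound 2, with a step of a 2.0-fold higher number from compound 3 to compound 4 (0.30 log units; within the scatter). In this assay compound 4 is thus estimated at 15 ug/mL, plausibly between 7 ug/mL and 35 ug/mL.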

Compound 4, half-maximal inhibitory concentration: 99.4 ug/mL
Compound 4: middle estimate off by 6.6-fold (0.82 log units), on the low side; measured number outside the range, above it.
By their numbers in this assay, from the lowest: compound 3; then compound 2; then compounds 1 and 4 (each within the scatter of the next).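

Replacing the hydroxy that sits meta to a hydroxy group and para to a large group with hydrogen gives a 13-fold higher number from compound 3 to compound 4 (1.12 log units; beyond the scatter) in this assay, so this single position carries most of the gain seen in the dihydroxyphenyl imine. The remaining hydroxy does not retain any of that gain, as a 2.9-fold higher number from compound 2 to compound 4 (0.46 log units; beyond the scatter) runs against it. Compared with the 4-chlorophenyl imine, the result is a 1.3-fold higher number from compound 1 to compound 4 (0.12 log units; within the scatter) and shows no real separation. No measurement here accounts for this.

Open, going by these compounds, is whether this hydroxy works alone, without the other hydroxy. Also open, on these data alone, is whether methoxy or an amine at the same carbon can stand in for it.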